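The source may hold more compounds than are shown below. What is called first, only, known or untested is meant among the compounds shown, and "the series" means these compounds.

Measured so far in a functional assay on HCT-116 cells (Homo sapiens) for antiproliferative activity, read by MTT assay, with a stated time of 72 h; a higher number here means a weaker inhibitor, a lower number a stronger inhibitor:
- compound 1 `C/C(C#Cc1ccccc1)=N\N/C(N)=N/S(=O)(=O)c1cc(C)c(Cl)cc1SCc1cccc(C(F)(F)F)c1` — 14000 nM
- compound 2 `Cc1cc(S(=O)(=O)/N=C(\N)N/N=C/C#Cc2ccccc2)c(SCc2ccc(C(F)(F)F)cc2)cc1Cl` — 70000 nM
- compound 3 `Cc1cc(S(=O)(=O)/N=C(\N)N/N=C/C#Cc2ccccc2)c(SCc2ccccc2Cl)cc1Cl` — 27000 nM

Compound 1 holds the lowest of the three numbers in this assay, but its gap to compound 3 lies within the scatter, and only its gap to compound 2 lies beyond it. For the measured compounds named here, the one single-point step among the measured compounds is a 2.6-fold lower number from compound 2 to compound 3 (0.41 log units; beyond the scatter), an exchange of the aryl group on the saturated chain carbon bound to a sulfur, the same place that changes here. It shows that this position tolerates aryl exchange with at most a modest shift in the number.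

Compound 4 `C/C(C#Cc1ccccc1)=N\N/C(N)=N/S(=O)(=O)c1cc(C)c(Cl)cc1SCc1cccc2ccccc12` differs from compound 1 by naphthalen-1-yl in place of 3-(trifluoromethyl)phenyl on a saturated chain carbon bound to a sulfur. Going by the values given here, no measured compound carries naphthalen-1-yl, so the step rests on the aryl-exchange precedent alone. A step no larger than that one is expected, with no direction established. The estimated step of no change at the digits printed from compound 1 to compound 4 (within the scatter) is therefore set near zero. Compound 4 is expected to give 14000 nM, within a range from 5000 nM to 40000 nM.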

Compound 4, half-maximal inhibitory concentration: 105000 nM
Beside the measured number, compound 4's estimate is 7.5-fold (0.88 log units) below it; measured number outside the range, above it.
By their numbers in this assay, from the lowest: compounds 1 and 3 (each within the scatter of the next); then compounds 2 and 4 (each within the scatter of the next).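

In this assay, a 7.5-fold higher number from compound 1 to compound 4 (0.88 log units; beyond the scatter) shows that aryl exchange on the saturated chain carbon bound to a sulfur can move the number further than a 2.6-fold lower number from compound 2 to compound 3 (0.41 log units; beyond the scatter) did, although those two steps stand on different compound pairs. The heavy-atom count of the group stays the same in the exchange of 3-(trifluoromethyl)phenyl for naphthalen-1-yl, so the shift at this position comes with no change in that count. No measurement here gives a reason for the shift.

From the compounds shown here alone, whether the higher number goes with the second aromatic ring or with the departure of the trifluoromethyl group stays open, and an unsubstituted phenyl or a naphthalen-2-yl group at this place would separate the two. Going by these compounds, how a pyridine ring or a longer chain at this place would read also stays open.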